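Shortening the hydroxamate linker of compound 1

The compounds below may be only part of what the source reports. "The series", "measured", "known", "first", "only" and "open" are said of these compounds alone.

Compound 1 `Cn1cc(-c2ccccc2Oc2ccccc2)c2cc(C(=O)NCCCCCCC(=O)NO)[nH]c2c1=O` was tested in an assay on isolated protein for inhibition of protein deacetylase HDAC6 (Homo sapiens), read by fluorescence (on this read-out higher numbers stand for weaker inhibition and lower numbers for stronger inhibition), where compound 1 gives 4.7 nM. A second compound, compound 2 `Cn1cc(-c2cc(C(C)(C)O)ccc2Oc2ccc(F)cc2F)c2cc(C(=O)NCc3ccc(C(=O)NO)cc3)[nH]c2c1=O`, shares the same core but carries a different side chain and a different hydroxamate-bearing arm; in this assay compound 2 gives 15.6 nM. Of the two numbers, compound 1 stands at the lower one, and the gap to compound 2 lies beyond the usual scatter of repeat measurements, so compound 1 is the stronger inhibitor of the pair.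

Compound 3 `Cn1cc(-c2ccccc2Oc2ccccc2)c2cc(C(=O)NCCCCC(=O)NO)[nH]c2c1=O` has not yet been measured. It differs from compound 1 in one place only: hydroxycarbamoyl in place of 2-(hydroxycarbamoyl)ethyl on a saturated chain carbon, four bonds along the chain from an amide-type nitrogen. In plain terms, the chain that carries the hydroxamate end group is cut shorter by two chain carbons, while the end group itself and everything else stay the same.

Among the measured compounds shown here, no measured pair in this set shows what such a shortening does, so the expectation rests on the change alone. The step from compound 1 to compound 3 is expected to be an 8.5-fold higher number from compound 1 to compound 3 (0.93 log units; beyond the scatter), a clear move toward weaker inhibition in this assay. Compound 3 is therefore estimated at 40 nM, with a likely range from 10 nM to 200 nM.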

Compound 3, half-maximal inhibitory concentration: 4 nM
Beside the measured number, compound 3's estimate is 10-fold (1.00 log units) above it; measured number below the stated range.
By their numbers in this assay, from the lowest: compounds 3 and 1 (each within the scatter of the next); then compound 2.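

In this assay, putting hydroxycarbamoyl in place of 2-(hydroxycarbamoyl)ethyl on this saturated chain carbon gives a 1.2-fold lower number from compound 1 to compound 3 (0.07 log units; within the scatter) and so leaves the two compounds indistinguishable on this read-out. Among the compounds shown here, this is the first pair in the set that differs in chain length alone, since compound 2 differs from compound 1 in several places at once, and it shows that inhibition of this enzyme stays in the same low range at both lengths when the shared core and the hydroxamate end group are kept. Nothing available here explains why the two chain lengths read alike.

What the compounds shown leave open is how far this tolerance extends, as a longer chain such as 7-(hydroxycarbamoyl)heptyl or a still shorter one such as (hydroxycarbamoyl)methyl could read differently. As far as these compounds go, it is also open whether the end group matters as much as its distance from the core, which a carboxylic acid in place of the hydroxamate on the same chain would test, and whether the same shortening would read alike with the side chain of compound 2.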